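This account rests on a few compounds, and the source may have more. Where it says the series, first, only, none or still open, it means among the compounds named here.

Compound 1 `CCNC(=O)Nc1cccc2c1CN(C)CC2c1ccccc1` gives > 80 mg/kg in a functional assay on the whole organism for inhibition of sodium-dependent dopamine transporter (Mus musculus); on this read-out higher numbers stand for an effect only at larger amounts of compound and lower numbers for an effect already at smaller amounts; this is a limit of the assay, not a number. Compound 2 `CCCCNCC(=O)Nc1cccc2c1CN(C)CC2c1ccccc1` gives 25 mg/kg in this assay. Compound 3 `CCNCCC(=O)Nc1cccc2c1CN(C)CC2c1ccccc1` gives 190 mg/kg.

Compound 1 therefore stands only at a limit in this assay. The step of an at least 3.2-fold lower number from compound 1 to compound 2 (0.50 log units; beyond the scatter) is read against that limit, and the step that the limit leaves unreadable from compound 1 to compound 3. Between the two compounds with numbers, the step of a 7.6-fold higher number from compound 2 to compound 3 (0.88 log units; beyond the scatter).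

Compound 4 `CC(C)NCCC(=O)Nc1cccc2c1CN(C)CC2c1ccccc1` carries 2-(isopropylamino)ethyl in place of ethylamino on a carbonyl carbon. Among the compounds with values here, this change is closest to the one leading to compound 3, whose value 190 mg/kg is the nearest guide, and the step of a 7.6-fold higher number from compound 2 to compound 3 (0.88 log units; beyond the scatter) points the same way. Compound 4 is expected to give 200 mg/kg, within 80 mg/kg to 500 mg/kg. The expected step is a step that the limit leaves unreadable from compound 1 to compound 4.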

Compound 4, dose for half-maximal effect: about 200 mg/kg
Beside the measured number, compound 4's estimate shows no gap at the digits printed; measured number inside the range.
By their numbers in this assay, from the lowest: compound 2; then compounds 3 and 4 (each within the scatter of the next).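

In this assay, methyl in place of hydrogen on a saturated chain carbon bound to an amine nitrogen and a saturated chain carbon makes no readable difference, with a 1.1-fold higher number from compound 3 to compound 4 (0.02 log units; within the scatter). The butylamino side chain keeps its clear lead, with an 8.0-fold higher number from compound 2 to compound 4 (0.90 log units; beyond the scatter). The step from compound 1 cannot be read, because that compound stands only at a limit: the limit of > 80 mg/kg in this assay, at which 1 of the 4 values shown sits.

Still open, from the compounds shown here alone, is whether the lower number of compound 2 comes from its butylamino end or from the length of the chain to the carbonyl carbon. A 2-(butylamino)ethyl group on that carbonyl carbon would separate the two.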